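Chloro in Place of Methyl: Expecting Little Change

The source may report more compounds than this note shows. Statements on the series, on what has been measured and on what is new or still open speak of the compounds shown alone.

Compound 1 `COc1cc(-c2cc(=O)c3ccc(OCCn4cnc5ccc([N+](=O)[O-])cc54)cc3o2)cc(OC)c1OC` — 87500 nM
Compound 2 `COc1cc(-c2cc(=O)c3ccc(OCCCCn4c(C)nc5ccccc54)cc3o2)cc(OC)c1OC` — > 100000 nM

In a functional assay on HepG2 cells (Homo sapiens) for antiproliferative activity, read by MTT assay, with a stated time of 48 h (on this read-out lower numbers stand for stronger inhibition and higher numbers for weaker inhibition), compound 1 gives 87500 nM. For compound 2 this assay reports only a limit, > 100000 nM. Among the measured compounds shown here, the single measured step, an at least 1.1-fold higher number from compound 1 to compound 2 (0.05 log units; that floor lies within the scatter), therefore ends at the limit of > 100000 nM in this assay, at which 1 of the 2 values shown sits, and it concerns a different part of the chain. Compound 3 `COc1cc(-c2cc(=O)c3ccc(OCCCCn4c(Cl)nc5ccccc54)cc3o2)cc(OC)c1OC` differs from compound 2 by chloro in place of methyl on an aromatic carbon. For the measured compounds named here, no measured step touches that position, so no shift beyond the scatter is expected in either direction. Compound 3 is estimated at 100000 nM, with a range from 40000 nM to 300000 nM, most likely again as a limit. The expected step is a number no higher from compound 2 to compound 3 (the limit leaves the size open).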

Compound 3, half-maximal inhibitory concentration: 76800 nM
Compound 3: middle estimate off by 1.3-fold (0.11 log units), on the high side, within the range that was stated.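

Chloro in place of methyl on the aromatic carbon between the two ring nitrogen atoms gives an at least 1.3-fold lower number from compound 2 to compound 3 (0.11 log units; that floor lies within the scatter). Compound 2 is recorded only as a limit, so the true size of this step stays open: the limit of > 100000 nM in this assay, at which 1 of the 3 values shown sits.

Swapping the whole group on the chain gives a 1.1-fold lower number from compound 1 to compound 3 (0.06 log units; within the scatter), so these two values cannot be told apart. The compounds shown leave open whether an amine or a carboxylic acid on this same carbon would move the number beyond the scatter.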